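The source may report more compounds than this note shows. Statements on the series, on what has been measured and on what is new or still open speak of the compounds shown alone.

In a functional assay on SiHa cells (Homo sapiens) for inhibition (on this read-out higher numbers stand for weaker inhibition and lower numbers for stronger inhibition), three compounds have been measured:

compound 1 `COc1cc(/C=C/C(=O)c2cccc(NC(=O)c3cc(Cl)cc(Cl)c3)c2)ccc1O` gives 17.7 ug/mL
compound 2 `COc1cc(/C=C/C(=O)c2cccc(N)c2)ccc1O` gives 12.3 ug/mL
compound 3 `COc1cc(/C=C/C(=O)c2cccc(NC(=O)c3ccc(Cl)c(Cl)c3)c2)ccc1O` gives 25.3 ug/mL

Compound 3, at 25.3 ug/mL in this assay, lies within the scatter of its 3,5-dichlorophenyl counterpart (a 1.4-fold higher number from compound 1 to compound 3 (0.16 log units; within the scatter)) but modestly clear of the compound with hydrogen on the nitrogen (a 2.1-fold higher number from compound 2 to compound 3 (0.31 log units; beyond the scatter)).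

Compound 4 `CCCC(=O)Nc1cccc(C(=O)/C=C/c2ccc(O)c(OC)c2)c1` has not yet been measured. It puts propyl in place of 3,4-dichlorophenyl on a carbonyl carbon.

Among the measured compounds shown here, no measured step makes this exact exchange. The nearest evidence comes from replacing the whole acyl group with hydrogen. For compound 3 that spans only a modest gap (a 2.1-fold higher number from compound 2 to compound 3 (0.31 log units; beyond the scatter)), and for compound 1 it stays within the scatter (a 1.4-fold lower number from compound 1 to compound 2 (0.16 log units; within the scatter)). A small move toward a lower number is therefore expected, not clearly beyond the scatter (a 1.4-fold lower number from compound 3 to compound 4 (0.15 log units; within the scatter)). In this assay compound 4 is estimated at 18 ug/mL with an expected range from 10 ug/mL to 33 ug/mL for the measurement.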

Compound 4, half-maximal inhibitory concentration: 3.94 ug/mL
Compound 4: middle estimate off by 4.6-fold (0.66 log units), on the high side; measured number below the stated range.
By their numbers in this assay, from the lowest: compound 4; then compounds 2, 1 and 3 (each within the scatter of the next, the first and the last beyond it).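

In this assay, the amide nitrogen now proves able to carry an acyl group with stronger inhibition than the free amine, as propylcarbonyl in place of hydrogen shows (a 3.1-fold lower number from compound 2 to compound 4 (0.49 log units; beyond the scatter)), whereas neither dichlorophenyl amide had fallen clearly below that amine. The group on the carbonyl carbon therefore decides the outcome, with propyl giving a lower number than either 3,4-dichlorophenyl (a 6.4-fold lower number from compound 3 to compound 4 (0.81 log units; beyond the scatter)) or 3,5-dichlorophenyl (a 4.5-fold lower number from compound 1 to compound 4 (0.65 log units; beyond the scatter)), and compound 4 is the strongest of the four. Nothing given here accounts for this difference.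

On these data alone, whether the result follows from the propyl chain itself or from the absence of the dichlorophenyl ring remains open. Methyl, a longer chain such as pentyl, or an unsubstituted phenyl on the same carbonyl carbon would help separate these readings.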